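This account rests on a few compounds, and the source may have more. Where it says the series, first, only, none or still open, it means among the compounds named here.

Measured compounds:
compound 1 `COc1ccc(OCC(=O)Nc2cccc(NC(=O)c3ccc(N(C)C)cc3)c2)cc1OC` — in an assay on isolated protein for inhibition of Rho-associated protein kinase 2 (Homo sapiens), read by scintillation counting, radiometric assay and 33P incorporation, with a stated time of 40 min, in the presence of a further agent that is not named here (a higher number here means a weaker inhibitor, a lower number a stronger inhibitor), compound 1 gives > 10000 nM, which is a limit of the assay and not a number.
compound 2 `CC(=O)c1ccc(OCC(=O)Nc2cccc(NC(=O)c3ccc(N(C)C)cc3)c2)cc1F` — in this assay compound 2 gives 98 nM.
compound 3 `CCCC(=O)Nc1cccc(NC(=O)COc2ccc3c(=O)ccoc3c2)c1` — in this assay compound 3 gives 176 nM.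

Compound 3 has the highest of the two numbers shown, but its gap to compound 2 lies within the scatter, so no order between the two is claimed. Compound 1 sits at the limit of > 10000 nM in this assay, at which 1 of the 3 values shown sits, and gives no number to compare.

Among the compounds with values here, the only measured step is an at least 100-fold lower number from compound 1 to compound 2 (2.00 log units; beyond the scatter), a large change made at the oxygen on a saturated carbon. It says nothing about the nitrogen on the aromatic ring, which is where compound 4 `Cn1ccc(S(=O)(=O)Nc2cccc(NC(=O)COc3ccc4c(=O)ccoc4c3)c2)n1` departs from compound 3: a group of 9 heavy atoms (4 carbon, 2 nitrogen, 2 oxygen, 1 sulfur; one five-membered aromatic ring with 2 hetero atoms) in place of a group of 5 heavy atoms (4 carbon, 1 oxygen; no ring), on a nitrogen on an aromatic ring. Within the data shown here, no measured pair differs at that place, so the change has no precedent in this set; the sulfonyl-linked aromatic group entering in place of propylcarbonyl is untested here.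

With nothing to point either way, compound 4 is expected to stay close to compound 3, with a wide margin for an untested change. The expected step is a 1.7-fold higher number from compound 3 to compound 4 (0.23 log units; within the scatter). Compound 4 is thus estimated at 300 nM, between 70 nM and 1500 nM.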

Compound 4, half-maximal inhibitory concentration: 1350 nM
Compound 4: middle estimate off by 4.5-fold (0.65 log units), on the low side, within the range that was stated.
By their numbers in this assay, from the lowest: compounds 2 and 3 (each within the scatter of the next); then compound 4. At a limit, above all of these: compound 1.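

In this assay the nitrogen on an aromatic ring proves to be a place that responds to change: with the sulfonyl-linked group carrying one five-membered aromatic ring in place of propylcarbonyl, the shared core shows a 7.7-fold higher number from compound 3 to compound 4 (0.88 log units; beyond the scatter). Within the data shown here, this is the first measured step at this place, and it shows that a larger group with a ring is taken up here at a cost, yet compound 4 still gives a number and not a limit of the assay. No measurement shown offers a reason for this step.

The step changes the carbonyl link, the size of the group and the presence of a ring all at once, and the compounds shown do not tell which of these carries the loss. Open questions are whether a plain methanesulfonyl group on this nitrogen stays close to compound 3, and whether a benzoyl group or a longer acyl chain in place of propylcarbonyl moves the number up or down.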